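The source may hold more compounds than are shown below. What is called first, only, known or untested is meant among the compounds shown, and "the series" means these compounds.

Compound 1 `C=C1CC[C@H]2[C@@](C)(CCC(=O)[C@@]2(C)COC(C)=O)[C@@H]1C/C=C1/C(=O)OC[C@@H]1Oc1c(Cl)cc(Cl)c2cccnc12` gives 72000 nM in an ADME assay on SNB-19 cells (Homo sapiens) for cytotoxicity, read by MTT assay, with a stated time of 24 h; a higher number here means that more compound is tolerated, a lower number that less compound is tolerated; compound 2 `C=C1CC[C@H]2[C@@](C)(CCC(=O)[C@@]2(C)COC(C)=O)[C@@H]1C/C=C1/C(=O)OC[C@@H]1Oc1cccc2cccnc12` gives 21900 nM.

For the measured compounds named here, compound 1 stands highest of the two numbers, the only measured step from it being a 3.3-fold lower number from compound 1 to compound 2 (0.52 log units; beyond the scatter). Compound 3 `C=C1CC[C@H]2[C@@](C)(CCC(=O)[C@@]2(C)COC(C)=O)[C@@H]1C/C=C1/C(=O)OC[C@H]1Oc1c(Cl)cc(Cl)c2cccnc12` differs from compound 1 in that (the two compounds have the same atoms and bonds and differ only in configuration as drawn: 1 of 6 stereo elements differ; a stereocentre at a saturated ring carbon is drawn R in compound 1 and S in compound 3). Going by the values given here, that one measured step concerns quinolin-8-yl in place of 5,7-dichloroquinolin-8-yl, not a change of configuration, so no measured step bears on this move. Compound 3 is therefore expected to remain near its parent, the expected step being a 1.2-fold lower number from compound 1 to compound 3 (0.08 log units; within the scatter), not confidently beyond the scatter. Compound 3 is estimated at 60000 nM, within 25000 nM to 150000 nM.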

Compound 3, half-maximal cytotoxic concentration: > 100000 nM
Compound 3: no number, only a limit (the forecaster's own chance of this, stated with the estimate: 10%); middle value at least 1.6-fold (0.22 log units) from the limit.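

For compound 3 the result is a limit and not a number: the limit of > 100000 nM in this assay, at which 1 of the 3 values shown sits. Turning the stereocentre at a saturated ring carbon from R to S gives an at least 1.3-fold higher number from compound 1 to compound 3 (0.14 log units; that floor lies within the scatter) in this assay. This is the first sign that this centre can be changed without lowering the number, but the floor of the step lies within the scatter, so a real rise is not shown.

As far as these compounds go, how compound 3 would stand without its limit remains open, as does the S configuration with the unsubstituted quinolin-8-yl group of compound 2. The compounds shown also leave open what an amine on the quinolin-8-yl group would do.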